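Homologation of an alkyl carbamate on a selenocyanate scaffold

A few compounds are considered here, and "the series" means these few. Any claim that something is new, unique, unknown or untested is made for them only; others in the source may bear on it.

Measured so far:
compound 1, `COc1ccc(OC(=O)Nc2ccc([Se]C#N)cc2)cc1`: 23700 nM
compound 2, `CCCOC(=O)Nc1ccc([Se]C#N)cc1`: 28900 nM

Both compounds were tested in a functional assay on HTB-54 cells (Homo sapiens) for cytotoxicity, read by MTT assay, with a stated time of 72 h; on this read-out higher numbers stand for weaker inhibition of growth and lower numbers for stronger inhibition of growth. Compound 2 gives 28900 nM, which is the higher of the two numbers, while compound 1 gives 23700 nM; the gap between them lies within the scatter, so the two cannot be ordered. Compound 3 is `CCCCOC(=O)Nc1ccc([Se]C#N)cc1`. Relative to compound 2 the change is methyl in place of hydrogen on a saturated chain carbon, three bonds along the chain from an oxygen next to a carbonyl group, that is, propyl to butyl on the carbamate oxygen. Among the measured compounds shown here, no step between measured compounds bears on such a change, and nothing among the two measured compounds tells in which direction a longer chain should move the read-out. The step from compound 2 to compound 3 in this assay is therefore expected to be small, a 1.2-fold lower number from compound 2 to compound 3 (0.06 log units; within the scatter), and not beyond the scatter. Compound 3 is estimated at 25000 nM, with a range from 12000 nM to 52000 nM.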

Compound 3, concentration for 50% growth inhibition: 17200 nM
For compound 3 the middle estimate is 1.5-fold (0.16 log units) above the measured one, and the stated range covers the measured number.
By their numbers in this assay, from the lowest: compounds 3, 1 and 2 (each within the scatter of the next).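

In this assay, among the compounds shown here, the change from propyl to butyl on the carbamate oxygen gives the first step that can be read at this position, a 1.7-fold lower number from compound 2 to compound 3 (0.23 log units; within the scatter) on the scale of this measurement. Methyl in place of hydrogen on a saturated chain carbon, three bonds along the chain from an oxygen next to a carbonyl group, therefore leaves the read-out within the scatter, and the butyl carbamate cannot be ordered against the propyl carbamate. Nothing measured on these compounds offers an explanation for the size of this step.

As far as these compounds go, with a single step, it remains open whether a longer chain such as hexyl or octyl would move the number beyond the scatter. From the compounds shown here alone, how a branched chain such as isobutyl, or a chain ending in an amine or a carboxylic acid, would read at this position is also open.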